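Swapping bromo for iodo in a cytotoxicity series

This account rests on a few compounds, and the source may have more. Where it says the series, first, only, none or still open, it means among the compounds named here.

- compound 1 `Cc1ccc(-n2nc(-c3ccc(C(F)(F)F)cc3O)nc2-c2ccccc2O)cc1` gives 113000 nM
- compound 2 `CC(C)c1ccc(-n2nc(-c3ccc(C(F)(F)F)cc3O)nc2-c2ccccc2O)cc1` gives 144000 nM
- compound 3 `Oc1cc(C(F)(F)F)ccc1-c1nc(-c2ccccc2O)n(-c2ccc(Br)cc2)n1` gives 66800 nM

All three numbers come from a toxicity assay on PC-12 cells (Rattus norvegicus) for cytotoxicity, read by MTT assay (a lower number here means a stronger inhibitor, a higher number a weaker inhibitor), and they lie close together. Compound 3 stands at the low end of them, but only one of its two gaps clears the usual scatter. Its gap to the methyl compound is a 1.7-fold lower number from compound 1 to compound 3 (0.23 log units; within the scatter) and its gap to the isopropyl compound is a 2.2-fold lower number from compound 2 to compound 3 (0.33 log units; beyond the scatter) as the modest one.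

The next compound is compound 4 `Oc1cc(C(F)(F)F)ccc1-c1nc(-c2ccccc2O)n(-c2ccc(I)cc2)n1` which keeps the shared core and changes one group: iodo in place of bromo on an aromatic carbon so that 4-bromophenyl becomes 4-iodophenyl.

Among the compounds with values here, no measured compound carries iodo, so the evidence is indirect. The three measured steps all change the group at this one spot, and the third of them is a 1.3-fold higher number from compound 1 to compound 2 (0.11 log units; within the scatter) which is as small as the others. Even the largest barely passes the scatter. With compound 3 at 66800 nM and steps this small, no clear move in either direction is expected from this swap. The expected change is a 1.0-fold lower number from compound 3 to compound 4 (0.01 log units; within the scatter) and that would stay within the scatter. The estimate for compound 4 is 66000 nM with an expected range from 33000 nM to 130000 nM in this assay series.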

Compound 4, half-maximal inhibitory concentration: 73300 nM
Compound 4: middle estimate off by 1.1-fold (0.05 log units), on the low side; measured number inside the range.
By their numbers in this assay, from the lowest: compounds 3, 4, 1 and 2 (each within the scatter of the next, the first and the last beyond it).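

In this assay, going from 4-bromophenyl to 4-iodophenyl gives a very small step (a 1.1-fold higher number from compound 3 to compound 4 (0.04 log units; within the scatter)), so at this spot, para to a large group, bromo and iodo cannot be told apart. The earlier compounds shown here left one gap beyond the scatter, between bromo and isopropyl, but iodo does not repeat it: its step from the isopropyl compound (a 2.0-fold lower number from compound 2 to compound 4 (0.29 log units; within the scatter)) and its step from the methyl compound (a 1.5-fold lower number from compound 1 to compound 4 (0.19 log units; within the scatter)) both stay within the scatter. This places iodo within the scatter of all three other groups, and nothing measured here explains why the numbers at this spot stay so close together.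

The compounds shown leave open whether a group of a different kind at this spot, such as an amine or a carboxylic acid, would take the number clearly outside this narrow band. They also leave open whether a change elsewhere on the shared core, such as replacing the trifluoromethyl group with a nitrile, would matter more than any swap made here.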